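Furan-2-yl for phenyl on the amide carbonyl

This account rests on a few compounds, and the source may have more. Where it says the series, first, only, none or still open, it means among the compounds named here.

- Compound 1 `COc1ccc(S(=O)(=O)N2CCc3cccc(NC(=O)c4ccncc4)c32)cc1`: 8.6 nM
- Compound 2 `COc1ccc(S(=O)(=O)N2CCc3cccc(NCc4ccccc4)c32)cc1`: > 10000 nM
- Compound 3 `COc1ccc(S(=O)(=O)N2CCc3cccc(NC(=O)c4ccccc4)c32)cc1`: 192 nM

All three results come from a functional assay on HT-29 cells (Homo sapiens) for cytotoxicity; a higher number here means a weaker inhibitor, a lower number a stronger inhibitor. Compound 2 reads > 10000 nM, which is a limit of the assay and not a number. Among the compounds with values here, of the two actual numbers, compound 3 holds the higher at 192 nM, and the only comparison between numbers is a 22-fold higher number from compound 1 to compound 3 (1.35 log units; beyond the scatter).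

Next in line is compound 4 `COc1ccc(S(=O)(=O)N2CCc3cccc(NC(=O)c4ccco4)c32)cc1`, which keeps the shared core and the amide and differs only in the group on the carbonyl: furan-2-yl in place of phenyl on a carbonyl carbon. In short, furan-2-yl stands in place of phenyl on a carbonyl carbon.

The most relevant precedent is the large step at that same place, a 22-fold higher number from compound 1 to compound 3 (1.35 log units; beyond the scatter), where phenyl replaces pyridin-4-yl. It is a single pair, and furan-2-yl is a different ring, so only part of that gap is expected to carry over. The other two large steps, an at least 1100-fold higher number from compound 1 to compound 2 (3.06 log units; beyond the scatter) and an at least 52-fold lower number from compound 2 to compound 3 (1.71 log units; beyond the scatter), involve benzyl on the nitrogen and say little about this exchange.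

A moderate move towards a lower number is therefore expected, estimated as a 2.7-fold lower number from compound 3 to compound 4 (0.44 log units; beyond the scatter). For compound 4 the estimate is 70 nM, with an expected range of 20 nM to 250 nM.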

Compound 4, half-maximal inhibitory concentration: 9.5 nM
Beside the measured number, compound 4's estimate is 7.4-fold (0.87 log units) above it, outside the stated range (below it).
By their numbers in this assay, from the lowest: compounds 1 and 4 (each within the scatter of the next); then compound 3. At a limit, above all of these: compound 2.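

On a carbonyl carbon whose other neighbour is the amide-type nitrogen, phenyl is the ring that stands apart from the other two in this assay: furan-2-yl in place of phenyl gives a 20-fold lower number from compound 3 to compound 4 (1.31 log units; beyond the scatter), on this single pair, with one hydrogen-bond acceptor entering where phenyl has none. Furan-2-yl in place of pyridin-4-yl gives a 1.1-fold higher number from compound 1 to compound 4 (0.04 log units; within the scatter), so pyridin-4-yl is not the only ring in the series that reaches this range, and a five-membered ring serves as well as a six-membered one. Compound 2 stands at a limit of the assay and not at a number, and (furan-2-yl)carbonyl in place of benzyl on the nitrogen gives an at least 1000-fold lower number from compound 2 to compound 4 (3.02 log units; beyond the scatter), so the large gap seen with benzoyl also appears with a second acyl group.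

No measurement shown bears on why these rings differ. From the compounds shown here alone, how thiophen-2-yl, saturated tetrahydrofuran-2-yl or a furan-2-yl ring carrying an aminomethyl group would read on the same carbonyl carbon stays open, as does whether these results hold outside this assay.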